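The source may hold more compounds than are shown below. What is called first, only, known or untested is meant among the compounds shown, and "the series" means these compounds.

For the measured compounds named here, compound 2 `Cn1nc(Cc2nnc(SCCCCCCCC(=O)Nc3ccc(Cl)cc3Cl)n2CCC=O)c2ccccc2c1=O` stands with the highest of the two numbers so far in an assay on isolated protein for binding affinity to interleukin-15 (Homo sapiens), read by surface plasmon resonance (a lower number here means tighter binding, a higher number weaker binding), giving 5900 nM; its nearest neighbour is compound 1 `Cn1c(Cc2nn(C)c(=O)c3ccccc23)nnc1SCCCCCCCC(=O)Nc1ccc(Cl)cc1Cl`, which in this assay gives 1300 nM. Compound 3 `Cn1nc(Cc2nnc(SCCCCCCCC(=O)Nc3ccc(Cl)cc3Cl)[nH]2)c2ccccc2c1=O` differs from compound 2 by hydrogen in place of 2-formylethyl on an aromatic nitrogen. Going by the values given here, the one step that bears on this change is a 4.5-fold higher number from compound 1 to compound 2 (0.66 log units; beyond the scatter), where the formyl-bearing chain entered at the same ring nitrogen and the number rose. Taking that chain away is therefore expected to lower the number again, by about a 3.9-fold lower number from compound 2 to compound 3 (0.59 log units; beyond the scatter). Compound 3 is estimated at 1500 nM, within a range from 600 nM to 4000 nM.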

Compound 3, dissociation constant: 2400 nM
For compound 3 the middle estimate is 1.6-fold (0.20 log units) below the measured one; the range from low to high includes it.
By their numbers in this assay, from the lowest: compounds 1 and 3 (each within the scatter of the next); then compound 2.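

In this assay, a 2.5-fold lower number from compound 2 to compound 3 (0.39 log units; beyond the scatter) shows that the 2-formylethyl group on this aromatic nitrogen goes with a higher number when compared with hydrogen as well as with methyl. Hydrogen and methyl at this position are not told apart, since a 1.8-fold higher number from compound 1 to compound 3 (0.27 log units; within the scatter) leaves the two compounds within the scatter. No evidence at hand explains what the 2-formylethyl group does here.

The compounds shown leave open whether the higher number of compound 2 goes with the carbon chain or with its formyl end. A propyl or 3-hydroxypropyl group on this nitrogen would separate the two.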